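Methyl to Benzyl Ester on a Thiophene-Bearing Core

The compounds below may be only part of what the source reports. "The series", "measured", "known", "first", "only" and "open" are said of these compounds alone.

Compound 1, `COC(=O)C1=C(C)NC(=S)NC1c1cccs1`, gives 1% in an assay on membranes from CHO cells for displacement of a labelled ligand from adenosine receptor A1 (Homo sapiens), read by scintillation counting, with a stated time of 60 min, tested at 1 uM; on this read-out lower numbers stand for less inhibition and higher numbers for more inhibition at the one concentration tested (going by the name of the read-out).
Compound 2, `COC(=O)C1=C(C)NC(=S)NC1c1ccsc1`, gives 3% in this assay.

Both measured compounds sit at very low inhibition in this assay. Among the compounds with values here, the difference between them, a number 2 percentage points higher from compound 1 to compound 2 (within the scatter), is within the scatter, so compound 2 and compound 1 cannot be told apart on these numbers; compound 2 simply carries the nominally higher of the two values, with compound 1 its only neighbour.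

Compound 3, `CC1=C(C(=O)OCc2ccccc2)C(c2ccsc2)NC(=S)N1`, has not yet been measured. It differs from compound 2 by phenyl in place of hydrogen on a saturated chain carbon bound to an oxygen next to a carbonyl group. Within the data shown here, the one measured step in this set changes a different place on the shared core and was within the scatter, so no measured step bears on this change, and nothing in the data points either way.

Among the measured compounds shown here, with two compounds near the floor of the read-out and no comparable precedent, the step of a number 2 percentage points higher from compound 2 to compound 3 (within the scatter) is expected to be none beyond the scatter. For compound 3 the estimate in this assay is therefore 5%, with a range from 0% to 20%.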

Compound 3, a percentage reported as inhibition, at one concentration (the size of the read-out at that concentration, not a potency): 3%
Estimate against measurement, compound 3: 2 percentage points above; the measured number falls inside the stated range.
By their numbers in this assay, from the lowest: compounds 1, 2 and 3 (each within the scatter of the next).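

In this assay, the change of methyl to benzyl, which puts phenyl in place of hydrogen on a saturated chain carbon bound to an oxygen next to a carbonyl group, gives no change at the digits printed from compound 2 to compound 3 (within the scatter). Within the data shown here, the earlier pair differed only in the thiophene group, so this is the first reading at the ester end of the molecule, and it shows that adding 6 heavy atoms and an aromatic ring there does not move the number beyond the scatter. Nothing measured here offers an explanation for this result.

All three compounds sit so close to the bottom of the read-out that a change lowering inhibition could hardly show, so the step speaks only against a clear rise at the one concentration tested, and it says nothing about potency. Still open, going by these compounds, is whether any other group at this place would lift the number beyond the scatter, such as a longer chain between the oxygen and the phenyl ring, an amine on that ring, or a free carboxylic acid in place of the ester.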